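The compounds below may be only part of what the source reports. "The series", "measured", "known", "first", "only" and "open" are said of these compounds alone.

Measured so far:
compound 1, `CCCCCCCCc1ccc(OCC(=O)Cn2nnnc2SC)cc1` — 22 nM
compound 2, `CCCCCCCCc1ccc(OCC(=O)Cn2nnnc2-c2cccc(Cl)c2)cc1` — 360 nM

Both numbers come from an assay on microsomes from brain for inhibition of Fatty-acid amide hydrolase 1 (Rattus norvegicus), read by fluorescence and HPLC, with a stated time of 60 min; a higher number here means a weaker inhibitor, a lower number a stronger inhibitor. Going by the values given here, on these two values compound 2 stands as the higher of the pair, and its only neighbour is compound 1, which gives 22 nM. Among the compounds with values here, the single measured step, a 16-fold higher number from compound 1 to compound 2 (1.21 log units; beyond the scatter), shows that swapping the methylsulfanyl group for an aromatic ring at this carbon of the shared core weakened inhibition clearly.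

Compound 3, `CCCCCCCCc1ccc(OCC(=O)Cn2nnnc2-c2ccc(S(=O)(=O)N(C)C)cc2)cc1`, is the next step: 4-(dimethylsulfamoyl)phenyl in place of 3-chlorophenyl on an aromatic carbon. Within the data shown here, no measured pair bears directly on this exchange, since the one step recorded swaps a small group for an aromatic ring rather than one ring for another. The new ring keeps the aromatic ring of compound 2 but carries a larger substituent. Among the measured compounds shown here, with only that one step as guidance, compound 3 is expected to land near compound 2 or somewhat weaker, a 1.4-fold higher number from compound 2 to compound 3 (0.14 log units; within the scatter). The estimate for compound 3 in this assay is 500 nM, within 100 nM to 3000 nM.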

Compound 3, half-maximal inhibitory concentration: 1400 nM
Estimate against measurement, compound 3: 2.8-fold (0.45 log units) below; the measured number falls inside the stated range.
By their numbers in this assay, from the lowest: compound 1; then compound 2; then compound 3.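

Going by these compounds alone, until now, the only change at this carbon of the shared core had replaced methylsulfanyl with an aromatic ring. Compound 3 shows that in this assay the ring's substituent also matters, with a 3.9-fold higher number from compound 2 to compound 3 (0.59 log units; beyond the scatter) when 4-(dimethylsulfamoyl)phenyl replaces 3-chlorophenyl, and the gap to the methylsulfanyl compound widens to a 64-fold higher number from compound 1 to compound 3 (1.80 log units; beyond the scatter) as a result. No accompanying measurement explains either step.

The two rings differ both in the group they carry and in where it sits on the ring, so these compounds cannot separate those two changes. As far as these compounds go, it also remains open whether plain phenyl, 4-chlorophenyl, a methyl group or an amine at this carbon would give a number closer to that of compound 1.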